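Moving the Chlorine from Compound 3 to Compound 4

The source may report more compounds than this note shows. Statements on the series, on what has been measured and on what is new or still open speak of the compounds shown alone.

Values measured so far in a functional assay, with a stated time of 25 min (on this read-out higher numbers stand for weaker inhibition and lower numbers for stronger inhibition), are these
- compound 1 `COc1cccc(NC(=O)CNC(=O)/C=C/c2ccc(O)c(OC)c2)c1` gives 94300 nM
- compound 2 `COc1ccc(NC(=O)CNC(=O)/C=C/c2ccc(O)c(OC)c2)cc1` gives 91200 nM
- compound 3 `COc1cc(/C=C/C(=O)NCC(=O)Nc2cccc(Cl)c2)ccc1O` gives 108000 nM

All three numbers lie within the usual scatter of one another, so compound 3 stands level with the other two. Compound 4 `COc1cc(/C=C/C(=O)NCC(=O)Nc2ccc(Cl)cc2)ccc1O` has not yet been measured. It differs from compound 3 in one place (4-chlorophenyl in place of 3-chlorophenyl on an amide-type nitrogen), with 4-chlorophenyl in place of 3-chlorophenyl on an amide-type nitrogen. The closest measured parallel is a similar shift of a methoxy group on that ring, a 1.0-fold lower number from compound 1 to compound 2 (0.01 log units; within the scatter). Exchanging methoxy for chloro also gave little, with a 1.1-fold higher number from compound 1 to compound 3 (0.06 log units; within the scatter) and a 1.2-fold higher number from compound 2 to compound 3 (0.07 log units; within the scatter). None of these steps exceeds the scatter, though a single parallel is thin evidence. No step beyond the scatter is therefore expected in this assay, and the estimated change is a 1.1-fold lower number from compound 3 to compound 4 (0.04 log units; within the scatter) without a firm direction. For compound 4 the expected value is 98000 nM, with an estimated range from 58000 nM to 165000 nM as the likely span.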

Compound 4, half-maximal inhibitory concentration: 101000 nM
Beside the measured number, compound 4's estimate is 1.0-fold (0.01 log units) below it, within the range that was stated.
By their numbers in this assay, from the lowest: compounds 2, 1, 4 and 3 (each within the scatter of the next).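

In this assay, moving the chlorine gives a 1.1-fold lower number from compound 3 to compound 4 (0.03 log units; within the scatter), so the indifference to the group's place seen earlier with methoxy now holds for chloro as well. Changing the group and its place together, 4-chlorophenyl in place of 3-methoxyphenyl on the amide-type nitrogen, also stays within the scatter, at a 1.1-fold higher number from compound 1 to compound 4 (0.03 log units; within the scatter). Chloro in place of methoxy, at a 1.1-fold higher number from compound 2 to compound 4 (0.04 log units; within the scatter), can now be read as a matched change in two settings, and the two readings agree: the same change on two cores in this assay, a 1.1-fold higher number (0.06 log units; within the scatter) from compound 1 to compound 3 and a 1.1-fold higher number (0.04 log units; within the scatter) from compound 2 to compound 4, 1.0-fold (0.01 log units) apart, within the scatter of two such steps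

Every step among these four compounds stays within the scatter, so it remains open whether any change on this ring can move the number beyond it. An amine or a carboxylic acid in place of the chloro or methoxy group would test this, as would a longer chain between the ring and the amide-type nitrogen.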